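Working notes: from compound 3 to compound 4

A few compounds are considered here, and "the series" means these few. Any claim that something is new, unique, unknown or untested is made for them only; others in the source may bear on it.

In an ADME assay on MT2 cells (Homo sapiens) for cytotoxicity, read by XTT assay, with a stated time of 4 days (on this read-out lower numbers stand for higher toxicity in this test and higher numbers for lower toxicity in this test), compound 1 `Cc1ccc(NC(=O)C(=O)NC(c2nc(C)c(CCO)s2)C2CCCCN2)cc1F` gives 85000 nM. Compound 2 `Cc1ccc(NC(=O)C(=O)NC(c2nc(C)c(CCO)s2)C2CCCCN2)c(F)c1` reads > 78800 nM, which is a limit and not a number. Compound 3 `Cc1ccc(NC(=O)C(=O)NC(c2nc(C)c(CO)s2)C2CCCCN2)cc1F` reads > 88000 nM, which is also a limit and not a number. Compound 3 therefore has no exact place in the series, and it shares that standing with one other compound.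

Compound 4 `Cc1nc(C(NC(=O)C(=O)Nc2ccc(F)cc2F)C2CCCCN2)sc1CO` differs from compound 3 in one place: 2,4-difluorophenyl in place of 3-fluoro-4-methylphenyl on an amide-type nitrogen. In words, 2,4-difluorophenyl stands in place of 3-fluoro-4-methylphenyl on an amide-type nitrogen.

The closest measured change is a step that the limit leaves unreadable from compound 1 to compound 2, with 2-fluoro-4-methylphenyl in place of 3-fluoro-4-methylphenyl on an amide-type nitrogen. For the measured compounds named here, it is the only measured change at this place, and it gives no readable size. The other measured change is an at least 1.0-fold higher number from compound 1 to compound 3 (0.01 log units; that floor lies within the scatter), with hydroxy in place of hydroxymethyl on a saturated chain carbon bound to an aromatic carbon. Neither step shows a change beyond the scatter, and no measurement covers 2,4-difluorophenyl itself. No step beyond the scatter is therefore expected in this assay, in either direction.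

The estimated step is a step that the limit leaves unreadable from compound 3 to compound 4. For compound 4 the expected value is 90000 nM, with an estimated range of 40000 nM to 200000 nM.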

Compound 4, half-maximal cytotoxic concentration: > 110000 nM
Compound 4 ended at the assay's limit; the forecaster's own chance of this, stated with the estimate: 70%; at least 1.2-fold (0.08 log units) between middle value and limit.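

In this assay compound 4 reads > 110000 nM, which is a limit and not a number. Compound 3 also stands at a limit, so no step can be read from compound 3 to compound 4. The compounds shown leave open whether 2,4-difluorophenyl in place of 3-fluoro-4-methylphenyl on an amide-type nitrogen moves the read-out at all, in either direction.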